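The compounds below may be only part of what the source reports. "The series", "measured", "known", "first", "only" and "open" are said of these compounds alone.

Compound 1 `COC1=CC(=O)C(O)=C(C/C=C(\C)CC[C@@]2(C)CCC=C(C)[C@H]2C)C1=O` carries a methoxy group on its quinone ring. In an ADME assay on L1210 cells (Mus musculus) for cytotoxicity, with a stated time of 48 h (on this read-out higher numbers stand for weaker inhibition and lower numbers for stronger inhibition), compound 1 gives 2 ug/mL, the lowest of the two numbers recorded; compound 2 `CC1=CCC[C@H]2[C@](C)(CC3=C(O)C(=O)C=C(N[C@@H](CO)C(=O)O)C3=O)[C@@H](C)CC[C@]12C` gives 3.8 ug/mL, which sits within the usual scatter of the value for compound 1. Compound 3 `C=C1[C@H](C)CCC[C@]1(C)CC/C(C)=C/CC1=C(O)C(=O)C=C(N[C@H](C(=O)O)[C@@H](C)O)C1=O` is reported only as a limit, > 10 ug/mL, and not as a number. Compound 4 `CC1=CCC[C@](C)(CC/C(C)=C/CC2=C(O)C(=O)C=C(N[C@H](CO)C(=O)O)C2=O)[C@@H]1C` differs from compound 1 in one place: (1-carboxy-2-hydroxyethyl)amino in place of methoxy on a double-bonded ring carbon. Within the data shown here, no measured pair shows this exact change. The step of a 2.5-fold higher number from compound 1 to compound 4 (0.40 log units; beyond the scatter) is expected to be small and toward weaker inhibition, since compound 2, bearing the same entering group on a different core, gives 3.8 ug/mL. Compound 4 is therefore estimated at 5 ug/mL, within a range from 2 ug/mL to 15 ug/mL.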

Compound 4, half-maximal inhibitory concentration: > 10 ug/mL
Compound 4: no number, only a limit; the forecaster's own chance of this, stated with the estimate: 30%; middle value at least 2.0-fold (0.30 log units) from the limit.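

Compound 4 is reported in this assay only as a limit, > 10 ug/mL, and not as a number. Within a single core, replacing methoxy with (1-carboxy-2-hydroxyethyl)amino on this double-bonded ring carbon gives an at least 5.0-fold higher number from compound 1 to compound 4 (0.69 log units; beyond the scatter), so the change clearly weakens inhibition here. The step is only a minimum, and its full size cannot be read: the limit of > 10 ug/mL in this assay, at which 2 of the 4 values shown sit.

The compounds shown leave open which part of the entering group carries this step. They also leave open how a simple amine or an ethoxy group would read at this position.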